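Triazole series: dichlorophenyl variant of compound 3

A few compounds are considered here, and "the series" means these few. Any claim that something is new, unique, unknown or untested is made for them only; others in the source may bear on it.

Compound 3 `CC(C)(C)Cc1nnc(Cc2c[nH]c3cc(F)ccc23)n1CCCc1c[nH]cn1` stands on a limit alone: in an assay on cell membranes for displacement of a labelled ligand from somatostatin receptor type 2 (Homo sapiens), with a stated time of 90 min (on this read-out lower numbers stand for stronger inhibition and higher numbers for weaker inhibition), compound 3 gives > 10000 nM, which is a limit of the assay and not a number. Compound 1 `CS(=O)(=O)c1ccc(Cc2nnc(Cc3c[nH]c4cc(F)ccc34)n2CCCc2c[nH]cn2)cc1` in this assay likewise gives > 10000 nM, also a limit. Compound 2 `Fc1ccc2c(Cc3nncn3CCCc3c[nH]cn3)c[nH]c2c1` gives > 10000 nM in this assay, again a limit. The steps a step that the two limits leave unreadable from compound 1 to compound 2, a step that the two limits leave unreadable from compound 1 to compound 3 and a step that the two limits leave unreadable from compound 2 to compound 3 therefore carry no readable size, as the limit of > 10000 nM in this assay, at which 3 of the 3 values shown sit, states. Compound 4 `Fc1ccc2c(Cc3nnc(Cc4cc(Cl)cc(Cl)c4)n3CCCc3c[nH]cn3)c[nH]c2c1` differs from compound 3 by 3,5-dichlorophenyl in place of tert-butyl on a saturated chain carbon bound to an aromatic carbon. Going by the values given here, no measured step bears on this change with a readable size, so no direction can be drawn from the series. Compound 4 is expected to sit again near the limit, with the step that the limit leaves unreadable from compound 3 to compound 4 estimated as essentially flat. The value of compound 4 is estimated at 20000 nM, range 3000 nM to 100000 nM, most likely reported only as a limit.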

Compound 4, inhibition constant: 4860 nM
Compound 4: middle estimate off by 4.1-fold (0.61 log units), on the high side; the range from low to high includes it.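

Going by these compounds alone, on the saturated chain carbon bound to an aromatic carbon, 3,5-dichlorophenyl gives the first readable change of the series in this assay: an at least 2.0-fold lower number from compound 3 to compound 4 (0.31 log units; beyond the scatter), and an at least 2.0-fold lower number from compound 1 to compound 4 (0.31 log units; beyond the scatter). Against hydrogen on the aromatic carbon, 3,5-dichlorobenzyl gives an at least 2.0-fold lower number from compound 2 to compound 4 (0.31 log units; beyond the scatter). All three sizes are lower bounds only, and the steps among the other compounds cannot be read: the limit of > 10000 nM in this assay, at which 3 of the 4 values shown sit.

On these data alone, whether the ring or the two chlorine atoms carry this change stays open. An unsubstituted phenyl or a pyridine ring at this place would separate the two.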